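Swapping the tail of compound 2

The source may report more compounds than this note shows. Statements on the series, on what has been measured and on what is new or still open speak of the compounds shown alone.

- compound 1 `O=C1c2c[n+]([O-])c3ccccc3c2C(=O)c2c1c1ccccc1n2Cc1cn([C@@H]2C[C@H](O)[C@@H](CO)O2)nn1`: 50 nM
- compound 2 `O=C1c2c[n+]([O-])c3ccccc3c2C(=O)c2c1c1ccccc1n2Cc1cn(C[C@H](O)CO)nn1`: 400 nM
- compound 3 `CC1(C)OC[C@@H](Cn2cc(Cn3c4c(c5ccccc53)C(=O)c3c[n+]([O-])c5ccccc5c3C4=O)nn2)O1`: 340 nM

All three values come from a functional assay on HCT-116 cells (Homo sapiens) for cytotoxicity, read by MTT assay, with a stated time of 72 h; a higher number here means a weaker inhibitor, a lower number a stronger inhibitor. Compound 2 belongs to the weaker pair: a 1.2-fold lower number from compound 2 to compound 3 (0.07 log units; within the scatter) lies within the scatter, while an 8.0-fold higher number from compound 1 to compound 2 (0.90 log units; beyond the scatter) lies beyond it, as does a 6.8-fold higher number from compound 1 to compound 3 (0.83 log units; beyond the scatter).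

Compound 4 `O=C1c2c[n+]([O-])c3ccccc3c2C(=O)c2c1c1ccccc1n2CCCCN1CCCCC1` keeps the shared core but changes the tail: 3-(piperidin-1-yl)propyl in place of 1-(2,3-dihydroxypropyl)-1H-1,2,3-triazol-4-yl on a saturated chain carbon bound to an aromatic nitrogen. Read one bond further out, (1-(2,3-dihydroxypropyl)-1H-1,2,3-triazol-4-yl)methyl gives way to 4-(piperidin-1-yl)butyl.

Among the measured compounds shown here, no measured step removes the triazole, so none tests this change directly. The closest guides are the tail swaps above: two gave modest steps and one gave none beyond the scatter. A modest step is therefore a reasonable expectation, but its direction is uncertain. A lower number is slightly favoured, since compound 2 at 400 nM already sits among the weaker values. The estimated change is a 2.4-fold lower number from compound 2 to compound 4 (0.37 log units; beyond the scatter). Compound 4 is expected to give 170 nM, with an expected range of 35 nM to 800 nM.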

Compound 4, half-maximal inhibitory concentration: 200 nM
The estimate for compound 4 lay 1.2-fold (0.07 log units) below the measured number; low and high end bracket the measured number.
By their numbers in this assay, from the lowest: compound 1; then compounds 4, 3 and 2 (each within the scatter of the next).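

In this assay, the 1-(2,3-dihydroxypropyl)-1H-1,2,3-triazol-4-yl group on the saturated chain carbon bound to an aromatic nitrogen can give way entirely to 3-(piperidin-1-yl)propyl without a change beyond the scatter (a 2.0-fold lower number from compound 2 to compound 4 (0.30 log units; within the scatter)). Every earlier tail carried the triazole, whereas this one has a six-membered non-aromatic ring instead and goes from 2 hydrogen-bond donors to 0, so a value of this size needs neither the triazole nor the hydroxyl groups. No measurement here explains why the two tails perform alike.

Ring and chain change together in this swap, so their separate contributions cannot be told apart. A morpholine on the same chain, or a piperidine attached through the triazole, would help separate them and show whether such a tail can approach compound 1 at 50 nM.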